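A few compounds are considered here, and "the series" means these few. Any claim that something is new, unique, unknown or untested is made for them only; others in the source may bear on it.

Of the compounds shown here, two sharing one core have been measured in an assay on CHO cells for displacement of a labelled ligand from B1 bradykinin receptor (Rattus norvegicus); a lower number here means a stronger inhibitor, a higher number a weaker inhibitor. Compound 1 `Cc1noc(-c2c(F)cccc2-c2ccc([C@@H](C)Nc3nccc(Cl)c3NC(=O)CC#N)cc2)n1` gives 81 nM in this assay. Compound 2 `COC(=O)c1c(Cl)cccc1-c1ccc([C@@H](C)Nc2nccc(Cl)c2NC(=O)CC#N)cc1` gives 35.7 nM in this assay. Of these two numbers, compound 1 has the higher one, and the gap to compound 2 lies beyond the scatter, so compound 2 is the stronger binder of the pair.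

Compound 3 `C[C@@H](Nc1nccc(Cl)c1NC(=O)CC#N)c1ccc(-c2cccc(F)c2-c2nnn(C)n2)cc1` has not yet been measured. It differs from compound 1 in a single place: 2-methyl-2H-tetrazol-5-yl in place of 3-methyl-1,2,4-oxadiazol-5-yl on an aromatic carbon. Both groups are small five-membered aromatic rings carrying a methyl group and standing on the same aromatic carbon, so the change swaps one heteroaromatic ring for a close relative. Going by the values given here, no measured pair here isolates such a swap, so the size of the step can only be expected, not read off. The step of a 1.1-fold lower number from compound 1 to compound 3 (0.03 log units; within the scatter) is expected to stay within the scatter, in no clear direction. Compound 3 is therefore estimated at 75 nM in this assay, with a likely range from 25 nM to 220 nM.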

Compound 3, inhibition constant: 119 nM
Beside the measured number, compound 3's estimate is 1.6-fold (0.20 log units) below it; the measured number falls inside the stated range.
By their numbers in this assay, from the lowest: compound 2; then compounds 1 and 3 (each within the scatter of the next).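

Measured in this assay, replacing the 3-methyl-1,2,4-oxadiazol-5-yl group with 2-methyl-2H-tetrazol-5-yl gives a 1.5-fold higher number from compound 1 to compound 3 (0.17 log units; within the scatter) as the step. Going by these compounds alone, this is the first pair here that differs in one place only, and it shows that on this aromatic carbon, ortho to a fluoro group, the read-out does not separate these two methyl-bearing five-membered rings, even though the count of hydrogen-bond acceptors goes from 3 to 4 and the oxygen is gone from the ring. No measurement available here offers an explanation for why the two rings read alike.

The compounds shown do not reveal whether a five-membered aromatic ring is needed on this carbon at all, since compound 2 carries a methyl ester but also differs from compound 1 in a second place, so it cannot answer that question. A carboxylic acid or a primary amide on the same carbon, with the fluoro group kept, would test this directly, and the same ring without its methyl group would show what that methyl contributes.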